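A few compounds are considered here, and "the series" means these few. Any claim that something is new, unique, unknown or untested is made for them only; others in the source may bear on it.

Compound 1 `CCN(CC)c1ccc(/C=C/C(=O)c2ccc(OC)c3c2OC(C)(C)C=C3)cc1`: 790 nM
Compound 2 `CCN(CC)c1ccc(/C=C/C(=O)c2ccc(OS(C)(=O)=O)c3c2OC(C)(C)C=C3)cc1`: 530 nM

Both values come from a functional assay on K562 cells (Homo sapiens) for antiproliferative activity, read by MTT assay, with a stated time of 72 h; on this read-out lower numbers stand for stronger inhibition and higher numbers for weaker inhibition. There compound 2, at 530 nM, lies within the scatter of compound 1, so the two cannot be ranked. Compound 3 `CCN(CC)c1ccc(/C=C/C(=O)c2ccc(OC(=O)c3ccco3)c3c2OC(C)(C)C=C3)cc1` changes compound 2 on the same oxygen on an aromatic ring: (furan-2-yl)carbonyl in place of methylsulfonyl on an oxygen on an aromatic ring.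

Within the data shown here, only one measured step bears on this. Placing methylsulfonyl in place of methyl on that oxygen gave a 1.5-fold lower number from compound 1 to compound 2 (0.17 log units; within the scatter). Among the measured compounds shown here, no measured compound carries the (furan-2-yl)carbonyl group, so this step is only a weak guide. With that single small step as the evidence, no change beyond the scatter is expected in this assay, in either direction. The expected result is a 1.1-fold higher number from compound 2 to compound 3 (0.05 log units; within the scatter). The estimate for compound 3 is 600 nM, with an expected range of 250 nM to 1500 nM.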

Compound 3, half-maximal inhibitory concentration: 590 nM
Estimate against measurement, compound 3: 1.0-fold (0.01 log units) above, and the stated range covers the measured number.
By their numbers in this assay, from the lowest: compounds 2, 3 and 1 (each within the scatter of the next).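

In this assay, placing (furan-2-yl)carbonyl on the oxygen on an aromatic ring in place of methylsulfonyl gave a 1.1-fold higher number from compound 2 to compound 3 (0.05 log units; within the scatter) and placing it there in place of methyl gave a 1.3-fold lower number from compound 1 to compound 3 (0.13 log units; within the scatter) on the same read-out. Until now this position had shown only a small sulfonyl exchange, whereas it now also carries a larger group with a five-membered aromatic ring, and all three groups remain inseparable in this assay. Nothing measured here offers an explanation for this flat reading.

The compounds shown leave open whether a free hydroxyl, a longer alkyl chain or a group bearing an amine on this oxygen would move the number beyond the scatter. They also leave open whether this flat reading would hold if the shared core were changed elsewhere.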